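The compounds below may be only part of what the source reports. "The series", "measured", "known", "first", "only" and "open" are said of these compounds alone.

In a functional assay on PC-3 cells (Homo sapiens) for inhibition, read by MTT assay, with stated times of 18 h and 4 h (on this read-out higher numbers stand for weaker inhibition and lower numbers for stronger inhibition), compound 1 `CCCOP(=O)(O)OCCSC(=S)N1CCCC1`, which already carries pyrrolidin-1-yl, reads > 100000 nM, and this is a limit of the assay and not a number. Compound 2 `CCCCCCOP(=O)(O)OCCSC(=S)N1CCCCCC1` also gives only a limit, > 100000 nM. Compound 2 therefore stands at the limit of > 100000 nM in this assay, at which 2 of the 2 values shown sit. Compound 3 `CCCCCCOP(=O)(O)OCCSC(=S)N1CCCC1` differs from compound 2 by pyrrolidin-1-yl in place of azepan-1-yl on a thiocarbonyl carbon, with pyrrolidin-1-yl in place of azepan-1-yl on a thiocarbonyl carbon. Within the data shown here, no measured step is available, and no change beyond the usual scatter is expected in this assay, in either direction. The estimated step is a number no higher from compound 2 to compound 3 (the limit leaves the size open). Compound 3 is expected at 100000 nM, with an estimated range of 40000 nM to 200000 nM.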

Compound 3, half-maximal inhibitory concentration: > 100000 nM
Compound 3 gave a limit, no number; the forecaster's own chance of this, stated with the estimate: 85%; the middle value sits exactly at the limit.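

Among these compounds, compound 1, compound 2 and compound 3 all give only a limit of the assay in this assay, so no step among them can be read: the limit of > 100000 nM in this assay, at which 3 of the 3 values shown sit. The compounds shown leave open whether pyrrolidin-1-yl and azepan-1-yl differ at all in this read-out.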